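This account rests on a few compounds, and the source may have more. Where it says the series, first, only, none or still open, it means among the compounds named here.

Working notes on the series. Within the data shown here, compound 1 `CCN(CC)S(=O)(=O)c1ccc(S(=O)(=O)N2CCC[C@@H](C(=O)NC3CN(C(=O)OC(C)(C)C)C3)C2)cc1` and compound 2 `CCOC(=O)[C@@H]1C[C@H](O)CN(S(=O)(=O)c2ccc(S(=O)(=O)N(CC)CC)cc2)C1` are the two measured members; they differ from one another in several places at once, so no single step connects them. In a functional assay on MIA PaCa-2 cells (Homo sapiens) for inhibition, read by MTT assay, with a stated time of 7 days (a higher number here means a weaker inhibitor, a lower number a stronger inhibitor), compound 1 gives 200 nM, the lowest of the two numbers recorded so far. In this assay compound 2 gives 1300 nM, a higher number, and the gap between these two lies beyond the scatter. Compound 3 `CCN(CC)S(=O)(=O)c1ccc(S(=O)(=O)N2CCC[C@@H](C(=O)N3CCN(c4nc(C)no4)CC3)C2)cc1` has not yet been measured. It differs from compound 1 in one place (4-(3-methyl-1,2,4-oxadiazol-5-yl)piperazin-1-yl in place of (1-(tert-butoxycarbonyl)azetidin-3-yl)amino on a carbonyl carbon). Among the measured compounds shown here, no step between measured compounds covers a change of this kind, so nothing in the recorded numbers fixes its size or direction. The expectation for compound 3 is a modest step towards a higher number, as a 2.0-fold higher number from compound 1 to compound 3 (0.30 log units; within the scatter), with a step of no size beyond the scatter also plausible. Compound 3 is estimated at 400 nM, within a range from 80 nM to 2000 nM.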

Compound 3, half-maximal inhibitory concentration: 250 nM
Beside the measured number, compound 3's estimate is 1.6-fold (0.20 log units) above it; low and high end bracket the measured number.
By their numbers in this assay, from the lowest: compounds 1 and 3 (each within the scatter of the next); then compound 2.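

In this assay, 4-(3-methyl-1,2,4-oxadiazol-5-yl)piperazin-1-yl in place of (1-(tert-butoxycarbonyl)azetidin-3-yl)amino on a carbonyl carbon gives a 1.3-fold higher number from compound 1 to compound 3 (0.10 log units; within the scatter), so two groups with the same count of heavy atoms but different rings are interchangeable at this position in this read-out. Among these compounds, the hydrogen-bond donor of the leaving group has no counterpart in the entering group, and this exchange still stays within the scatter. No measured property of either group bears on this result.

The compounds shown leave open whether a much smaller group on this carbonyl carbon, such as dimethylamino or a carboxylic acid in place of the amide, would stay within the scatter of compound 1. Going by these compounds, whether the tert-butoxycarbonyl group itself contributes also stays open, as would be tested by the free azetidin-3-ylamino group.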